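This account rests on a few compounds, and the source may have more. Where it says the series, first, only, none or still open, it means among the compounds named here.

Measured compounds in a functional assay on K562 cells (Homo sapiens) for cytotoxicity, read by MTT assay, with a stated time of 72 h; on this read-out higher numbers stand for lower toxicity in this test and lower numbers for higher toxicity in this test:
compound 1 `CS/C(=N\C(=O)c1cc(-c2ccccc2)nc2ccccc12)NC(=O)c1cc(-c2ccccc2)nc2ccccc12` gives > 100000 nM, which is a limit of this assay and not a number.
compound 2 `C[Se]/C(=N\C(=O)c1cc(-c2ccccc2)nc2ccccc12)NC(=O)c1cc(-c2ccccc2)nc2ccccc12` gives 73100 nM.
compound 3 `C[Se]/C(=N\C(=O)c1cnc2ccccc2c1)NC(=O)c1cnc2ccccc2c1` gives 74800 nM.

Compound 2 and compound 3 share the selenium-bearing group and differ in their cores; the difference between the two cores is not broken down here. Their values in this assay sit within the scatter of each other, so no order between them is claimed.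

Within the core of compound 2, the change to compound 1 is a group of 2 heavy atoms (1 carbon, 1 sulfur; no ring) in place of a group of 2 heavy atoms (1 carbon, 1 selenium; no ring), on a carbon with a double bond to nitrogen. The measured step is an at least 1.3-fold higher number from compound 2 to compound 1 (0.13 log units; that floor lies within the scatter); because compound 1 sits at the limit of > 100000 nM in this assay, at which 1 of the 3 values shown sits, only the floor of that step is known.

Compound 4 `CS/C(=N\C(=O)c1cnc2ccccc2c1)NC(=O)c1cnc2ccccc2c1` is not yet measured. It stands to compound 3 as compound 1 stands to compound 2: the change is a group of 2 heavy atoms (1 carbon, 1 sulfur; no ring) in place of a group of 2 heavy atoms (1 carbon, 1 selenium; no ring), on a carbon with a double bond to nitrogen, the same change made on the same kind of carbon, with the same neighbours around the place. Given that the earlier step gave only a floor, the expected step from compound 3 to compound 4 is estimated as a 1.4-fold higher number from compound 3 to compound 4 (0.15 log units; within the scatter), resting on the single measured step from compound 2 to compound 1. Compound 4 is therefore expected to give about 105000 nM in this assay, with a range estimated from 60000 nM to 200000 nM, and a real chance that the assay again reports only a limit.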

Compound 4, concentration lethal to 50% of the cells: > 100000 nM
Compound 4 ended at the assay's limit; the forecaster's own chance of this, stated with the estimate: 55%; the middle value does not contradict the limit.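

In this assay, methylsulfanyl in place of the selenium-bearing group, on a carbon with a double bond to nitrogen, gives an at least 1.3-fold higher number from compound 3 to compound 4 (0.12 log units; that floor lies within the scatter). Set beside the earlier step, this shows the change carried to a second core with no sign of a reversal, though each step is known only as a floor: the same change on two cores in this assay, an at least 1.3-fold higher number (0.13 log units; that floor lies within the scatter) from compound 2 to compound 1 and an at least 1.3-fold higher number (0.12 log units; that floor lies within the scatter) from compound 3 to compound 4; the limit leaves it open whether they differ

What the pair of steps does not show is the true size of the change on either core, or a separation between the methylsulfanyl and selenium-bearing compounds beyond the scatter, since both methylsulfanyl compounds give no number that can be compared: the limit of > 100000 nM in this assay, at which 2 of the 4 values shown sit.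

The compounds shown leave open how other groups on the same carbon, such as an amine or a longer chain like ethylsulfanyl, would read in this assay, and whether any of them would move the values away from the limit. Among these compounds, they also leave open whether the change behaves the same way on a core carrying a further substituent such as a carboxylic acid, as only two cores appear here.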